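The source may report more compounds than this note shows. Statements on the series, on what has been measured and on what is new or still open speak of the compounds shown alone.

Compound 2 `CC#C[C@@H](CC(=O)O)c1ccc(OC[C@H]2COc3ccc(F)cc3O2)cc1`: 86%
Compound 1 `Cn1cncc1C(CC(=O)O)c1ccc(OCC2COc3ccc(Cl)cc3O2)cc1`: 62%

Both numbers come from a functional assay on HEK293 cells for agonist activity at Free fatty acid receptor 1 (Homo sapiens), read by fluorescence and calcium flux, with a stated time of 10 min; a higher number here means a larger maximal response, a lower number a smaller maximal response. Among the compounds with values here, of the two compounds measured so far, compound 2 stands highest in this assay ; compound 1 lies lower by a gap beyond the usual scatter. Within the data shown here, the two compounds do not differ in a single place, so no measured step exists to guide the next change.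

Compound 3 `CC#C[C@@H](CC(=O)O)c1ccc(OC[C@H]2COc3ccc(CO)cc3O2)cc1` is not yet measured. It differs from compound 2 in one spot: hydroxymethyl in place of fluoro on an aromatic carbon. Among the measured compounds shown here, with no measured step of this kind, the size of the change in this assay cannot be read from the data. The expectation is a modest shift, if any, more likely downward than upward, and possibly within the scatter. Compound 3 is therefore estimated at 80%, with a range from 60% to 100%. This amounts to an expected step of a number 6 percentage points lower from compound 2 to compound 3 (within the scatter).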

Compound 3, largest response reached (Emax), in percent of the reference or control that the assay uses: 42%
The estimate for compound 3 lay 38 percentage points above the measured number; the whole stated range lies above it.
By their numbers in this assay, from the lowest: compound 3; then compound 1; then compound 2.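

The aromatic carbon that carries fluoro in compound 2 turns out to be sensitive: in this assay, hydroxymethyl in place of fluoro gives a number 44 percentage points lower from compound 2 to compound 3 (beyond the scatter). Within the data shown here, this is the first measured step, and it shows that a small change at this one spot, with the rest of the molecule the same, can markedly lower the maximal response, although compound 3 still reaches 42%. No measurement offered here explains this drop.

The compounds shown leave open whether the drop goes with the hydroxyl group or with the added carbon, since both enter together in this single change. Also open, on these data alone, is how a methyl, methoxy or aminomethyl group on this same aromatic carbon would compare with fluoro and hydroxymethyl.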